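Benzyloxy in Place of Methoxy on a Quinone Core

The compounds below may be only part of what the source reports. "The series", "measured", "known", "first", "only" and "open" are said of these compounds alone.

Measured compounds:
compound 1, `COc1ccc2c(c1)C(=O)C=CC2=O`: 22700 nM
compound 2, `O=C1C=C(Oc2ccco2)C(=O)c2ccccc21`: 37000 nM

Both measured compounds were tested in a functional assay on HeLa cells (Homo sapiens) for cytotoxicity; on this read-out lower numbers stand for stronger inhibition and higher numbers for weaker inhibition. In this assay compound 1 gives 22700 nM, and compound 2 gives 37000 nM. The two numbers lie within the usual scatter of each other, so compound 1 cannot be set apart from compound 2 on these data; it simply stands as one of two weakly active compounds.

The unmeasured compound 3, `O=C1C=CC(=O)c2cc(OCc3ccccc3)ccc21`, is reached from compound 1 by a single change: phenyl in place of hydrogen on a saturated chain carbon bound to an oxygen on an aromatic ring. Among the compounds with values here, no pair of measured compounds shows the effect of this kind of change, so there is no measured step to lean on. On the shared core of compound 1 and compound 2, both compounds give weak numbers in this assay, and there is no reason in the data to expect a large move in either direction.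

The step from compound 1 to compound 3 is therefore expected to be small, a 1.5-fold lower number from compound 1 to compound 3 (0.18 log units; within the scatter), at most slightly toward a lower number. Compound 3 is estimated at 15000 nM, with a range from 5000 nM to 45000 nM.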

Compound 3, half-maximal inhibitory concentration: 16800 nM
Compound 3: middle estimate off by 1.1-fold (0.05 log units), on the low side; the range from low to high includes it.
By their numbers in this assay, from the lowest: compounds 3, 1 and 2 (each within the scatter of the next, the first and the last beyond it).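

In this assay, phenyl in place of hydrogen on a saturated chain carbon bound to an oxygen on an aromatic ring gives a 1.4-fold lower number from compound 1 to compound 3 (0.13 log units; within the scatter) and so stays within the scatter. Within the data shown here, this is the first measured step at this place, and it shows that the shared core can carry the added phenyl, with its six heavy atoms and its six-membered aromatic ring of carbon only, without a number that can be told apart from that of compound 1. The change brings neither a clear gain nor a clear loss on this read-out, and nothing in the data shown accounts for that outcome.

The compounds shown leave open whether a phenyl bearing an amine or a carboxylic acid, or a longer chain carrying the phenyl, would move the number beyond the scatter. Among these compounds, with only this step at this place, they also leave open whether the same change would behave alike on the core of compound 2.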